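The source may hold more compounds than are shown below. What is called first, only, known or untested is meant among the compounds shown, and "the series" means these compounds.

In an ADME assay on HeLa cells (Homo sapiens) for cytotoxicity, read by ATP content, with a stated time of 3 days (a higher number here means that more compound is tolerated, a lower number that less compound is tolerated), compound 1 `O=c1n(Cc2cc3cnccc3n2CCCCF)c2cnccc2n1C1CC1` gives > 50000 nM, which is a limit of the assay rather than a number. Compound 2 `CS(=O)(=O)CCCn1c(Cn2c(=O)[nH]c3ccncc32)cc2cc(Cl)ccc21`, a differently built analogue measured alongside it, gives > 50000 nM, likewise a limit. Where compound 1 stands on the numbers shown is therefore only partly defined: it sits at the limit of > 50000 nM in this assay, at which 2 of the 2 values shown sit, and nothing among the measured values places it any lower.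

Compound 3 `CC(C)CCn1c(Cn2c(=O)n(C3CC3)c3ccncc32)cc2cnccc21` differs from compound 1 by isopropyl in place of 2-fluoroethyl on a saturated chain carbon, two bonds along the chain from an aromatic nitrogen; the same difference, cut one bond further out, reads 3-fluoropropyl to isobutyl, or 4-fluorobutyl to isopentyl. No measured pair among these compounds reports such a step, so its size is not known from the data. Given that compound 1 sits at the limit of > 50000 nM in this assay, at which 2 of the 2 values shown sit, the step from compound 1 to compound 3 in this assay is expected to be none beyond the scatter, a step that the limit leaves unreadable from compound 1 to compound 3. Compound 3 is thus estimated at 60000 nM in this assay, within 25000 nM to 200000 nM, most likely reported again only as a limit.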

Compound 3, half-maximal cytotoxic concentration: > 50000 nM
Compound 3 was reported as a limit; the forecaster's own chance of this, stated with the estimate: 85%; the middle value is on the limit's open side.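

Going by these compounds alone, compound 3, like compound 1, is reported only as a limit in this assay, so no step between the two can be read: the limit of > 50000 nM in this assay, at which 3 of the 3 values shown sit. The compounds shown leave open how much of any of them is actually tolerated, and whether isopropyl in place of 2-fluoroethyl changes that at all.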